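The source may report more compounds than this note shows. Statements on the series, on what has been measured and on what is new or still open speak of the compounds shown alone.

Measured compounds:
Compound 1, `COc1ccc(C(=O)NO)cc1CNc1ccc2c(c1)cc(C)c(=O)n2C`: 555 nM
Compound 2, `Cc1cc2cc(NS(=O)(=O)Cc3ccc(C(=O)NO)cc3)ccc2n(C)c1=O`: 360 nM

Both compounds were tested in an assay on isolated protein for inhibition of histone deacetylase 8 (Homo sapiens), read by fluorescence, with a stated time of 90 min; on this read-out higher numbers stand for weaker inhibition and lower numbers for stronger inhibition. Compound 1 gives 555 nM, and compound 2 gives 360 nM. These two numbers lie within the usual scatter of each other, so on the data shown neither compound stands apart from the other, and no ranking between them can be claimed.

Compound 3, `COc1cc(C(=O)NO)ccc1CS(=O)(=O)Nc1ccc2c(c1)cc(C)c(=O)n2C`, has not yet been measured. Compared with compound 2 it carries one change: methoxy in place of hydrogen on an aromatic carbon. Within the data shown here, no directly comparable pair among the measured compounds isolates this change, so there is no measured step to lean on. Compound 1 does carry a methoxy group, but it also differs from compound 2 in its linker, so the two compounds cannot be read as a test of the methoxy alone.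

With nothing to point either way, the step from compound 2 to compound 3 is expected to be small, a 1.1-fold higher number from compound 2 to compound 3 (0.05 log units; within the scatter), and not clearly beyond the scatter. Compound 3 is therefore estimated to give about 400 nM in this assay, with a plausible range from 150 nM to 1100 nM.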

Compound 3, half-maximal inhibitory concentration: 231 nM
For compound 3 the middle estimate is 1.7-fold (0.24 log units) above the measured one; measured number inside the range.
By their numbers in this assay, from the lowest: compounds 3, 2 and 1 (each within the scatter of the next, the first and the last beyond it).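

In this assay, among these compounds, a methoxy in place of hydrogen on this aromatic carbon, ortho to a large group and meta to a hydroxycarbamoyl group, gives a 1.6-fold lower number from compound 2 to compound 3 (0.19 log units; within the scatter) and so provides the first comparison in which the methoxy is the only change. At this position, the two added heavy atoms do not produce a step beyond the scatter, so the data show that the group can be present here without a clear change in the read-out, and compound 2 and compound 3 cannot be ranked. The data shown offer no independent measurement that could explain the result.

Hydrogen and methoxy are the only groups shown at this position, which leaves open how a fluorine atom, a hydroxyl group or a longer chain such as ethoxy would read here. Going by these compounds, it also remains open whether methoxy would give a step of similar size on another carbon of the same ring, or whether a larger series would show a step beyond the scatter.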